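A Thiazole Swap on a Sulfonamide Nitrogen

The source may report more compounds than this note shows. Statements on the series, on what has been measured and on what is new or still open speak of the compounds shown alone.

In a functional assay on MDA-MB-435 cells (Homo sapiens) for antiproliferative activity, read by sulforhodamine B assay, with a stated time of 72 h (on this read-out higher numbers stand for weaker inhibition and lower numbers for stronger inhibition), compound 1 `CCN1C(=O)CS/C1=N/Nc1nncc2ccccc12` gives 65 nM and compound 3 `S=C(NNc1nncc2ccccc12)Nc1ccccc1` gives 74 nM. Compound 2 `Cc1cc(C)nc(NS(=O)(=O)c2ccc(Nc3nncc4ccccc34)cc2)n1` has the lowest number of the three at 3.4 nM, a gap beyond the scatter from each of the others. Compound 4 `O=S(=O)(Nc1nccs1)c1ccc(Nc2nncc3ccccc23)cc1` has not yet been measured in this assay. It differs from compound 2 in one place: 1,3-thiazol-2-yl in place of 4,6-dimethylpyrimidin-2-yl on a sulfonamide nitrogen, with 1,3-thiazol-2-yl in place of 4,6-dimethylpyrimidin-2-yl on a sulfonamide nitrogen. Among the compounds with values here, no measured pair shows such a change, so any forecast is a judgement. The sulfonamide stays, and among the measured compounds only compound 2 at 3.4 nM carries one, so a modest weakening is the likeliest outcome. The expected change is a 2.6-fold higher number from compound 2 to compound 4 (0.42 log units; beyond the scatter). For compound 4 the estimated value is 9 nM, with an expected range of 2.5 nM to 40 nM.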

Compound 4, half-maximal inhibitory concentration: 36 nM
For compound 4 the middle estimate is 4.0-fold (0.60 log units) below the measured one, within the range that was stated.
By their numbers in this assay, from the lowest: compound 2; then compounds 4, 1 and 3 (each within the scatter of the next, the first and the last beyond it).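

Putting 1,3-thiazol-2-yl in place of 4,6-dimethylpyrimidin-2-yl on a sulfonamide nitrogen gives an 11-fold higher number from compound 2 to compound 4 (1.02 log units; beyond the scatter) in this assay and shows that this position is sensitive to the group it carries. The sulfonamide alone therefore does not secure the low number of compound 2. No measurement here accounts for the size of this step. From the compounds shown here alone, it remains open whether other groups on this nitrogen, such as phenyl, methyl or a pyrimidin-2-yl without its two methyl groups, would fall nearer compound 2 or compound 4.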